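Adding a second chloro: from compound 3 to compound 4

The compounds below may be only part of what the source reports. "The series", "measured", "known", "first", "only" and "open" are said of these compounds alone.

Measured in a functional assay on the whole organism (strain Wistar) for inhibition, with Rattus norvegicus as the target, read by paw edema, with stated times of 30 min and 3 h, at a dose of 200 mg/kg by the oral route; on this read-out higher numbers stand for more inhibition at the one dose given (going by the name of the read-out) and lower numbers for less inhibition:
Compound 1, `O=C(O)c1cc(-n2c(-c3ccccc3)cc3c2CCCC3)ccc1O`: >= 60%, which is a limit of the assay and not a number.
Compound 2, `COc1ccccc1-c1cc2c(n1-c1ccc(O)c(C(=O)O)c1)CCCC2`: 50%.
Compound 3, `O=C(O)c1cc(-n2c(-c3ccc(Cl)cc3)cc3c2CCCC3)ccc1O`: 40%.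

Compound 3 has the lowest of the two numbers; its nearest neighbour is compound 2, and the gap, a number 10 percentage points lower from compound 2 to compound 3 (within the scatter), lies within the scatter. Compound 4, `O=C(O)c1cc(-n2c(-c3ccc(Cl)c(Cl)c3)cc3c2CCCC3)ccc1O`, has not been measured. It differs from compound 3 by chloro in place of hydrogen on an aromatic carbon.

The measured step that bears most directly on this change is a number at least 20 percentage points lower from compound 1 to compound 3 (beyond the scatter), the same kind of substitution, which lowered the read-out beyond the scatter. The step of a number at least 10 percentage points lower from compound 1 to compound 2 (that floor lies within the scatter) is a different substitution and only reached the floor of the scatter. Given that one added chloro already lowered inhibition from compound 1, a second chloro on compound 4 is expected to lower it modestly again or leave it within the scatter, a number 8 percentage points lower from compound 3 to compound 4 (within the scatter). Compound 4 is therefore estimated at 32%, within 18% to 45%.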

Compound 4, a percentage reported as inhibition, in the whole organism at one dose (the size of the read-out at that dose, not a potency): 0%
For compound 4 the middle estimate is 32 percentage points above the measured one; the whole stated range lies above it.
By their numbers in this assay, from the lowest: compound 4; then compounds 3 and 2 (each within the scatter of the next). At a limit, above all of these: compound 1.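

In this assay, going by these compounds alone, the change from 4-chlorophenyl to 3,4-dichlorophenyl gives a number 40 percentage points lower from compound 3 to compound 4 (beyond the scatter), and compound 4 reads 0%, so a chloro at this place, ortho to the chloro group already there, can remove all the inhibition that was left, whereas the earlier compounds all kept a measurable effect. The 3,4-dichlorophenyl also loses heavily against the other aryl groups, with a number 50 percentage points lower from compound 2 to compound 4 (beyond the scatter) and a number at least 60 percentage points lower from compound 1 to compound 4 (beyond the scatter). The last of these steps starts from compound 1, whose value is a limit of the assay and not a number, so its true size stays unknown: the limit of >= 60% in this assay, at which 1 of the 4 values shown sits.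

The compounds shown leave open whether the loss belongs to this one place or to the pair of chloro groups together, and whether a methyl, an amine or a carboxylic acid at the same place would keep the inhibition. They also give no reason for the size of the fall, and a read-out at one dose says nothing about potency.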